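This account rests on a few compounds, and the source may have more. Where it says the series, first, only, none or still open, it means among the compounds named here.

Compound 1, `Cc1ccc(CNc2ncnc3c2ncn3[C@@H]2O[C@H](CO)[C@@H](O)[C@H]2O)cc1`: > 166000 nM
Compound 2, `OC[C@H]1O[C@@H](n2cnc3c(NCc4cc(F)cc(F)c4)ncnc32)C(O)C1O`: "not determined" (no result reported)

The read-out throughout is a functional assay on HOS cells (Homo sapiens) for antiproliferative activity, with a stated time of 72 h; on this read-out higher numbers stand for weaker inhibition and lower numbers for stronger inhibition. In this assay compound 1 gives > 166000 nM, which is a limit of the assay and not a number. Compound 1 therefore stands at the limit of > 166000 nM in this assay, at which 1 of the 2 values shown sits, with no single value of its own. Compound 2 has no result in this assay. Going by the values given here, with no two measured numbers in hand, no step between measured compounds can be drawn, and the structures alone carry the next compound.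

Compound 3 is `COc1cccc(CNc2ncnc3c2ncn3[C@@H]2O[C@H](CO)[C@@H](O)[C@H]2O)c1O`. It differs from compound 1 in one place: 2-hydroxy-3-methoxyphenyl in place of 4-methylphenyl on a saturated chain carbon bound to a nitrogen on an aromatic ring. The shared core is kept. Because compound 1 sits at the limit of > 166000 nM in this assay, at which 1 of the 2 values shown sits, the step to compound 3 in this assay is expected to be small or none beyond the scatter, with any movement more likely toward stronger inhibition than further weakening, since there is little room left in that direction. Compound 3 is expected near 150000 nM, within 30000 nM to 500000 nM. The step this estimate means is an at least 1.1-fold lower number from compound 1 to compound 3 (0.04 log units; that floor lies within the scatter), and a limit rather than a number remains the likelier outcome.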

Compound 3, half-maximal inhibitory concentration: > 166000 nM
Compound 3: no number, only a limit; the forecaster's own chance of this, stated with the estimate: 65%; middle value at least 1.1-fold (0.04 log units) from the limit.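

In this assay, going by these compounds alone, compound 3 gives > 166000 nM, which is a limit and not a number, and compound 1 also stands at a limit, so no step between compound 1 and compound 3 can be read. Both compounds rest at the same point: the limit of > 166000 nM in this assay, at which 2 of the 3 values shown sit.

The compounds shown leave open whether any group in this place would give a single number in this assay.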